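Swapping the Aryl Group on a Triazole-Bearing Nucleoside

The source may hold more compounds than are shown below. What is called first, only, known or untested is meant among the compounds shown, and "the series" means these compounds.

Within the data shown here, compound 2 `CCS[C@@H]1[C@H](SCC)[C@@H](Cn2cc(-c3ccc(OC)cc3)nn2)O[C@H]1n1cc(C)c(=O)[nH]c1=O` holds the only numerical value in this small set: in a functional assay on A549 cells (Homo sapiens) for cytotoxicity, read by MTT assay, with a stated time of 72 h (on this read-out higher numbers stand for an effect only at larger amounts of compound and lower numbers for an effect already at smaller amounts), compound 2 gives 38800 nM. Compound 1 `CCS[C@@H]1[C@H](SCC)[C@@H](Cn2cc(-c3ccc(F)cc3)nn2)O[C@H]1n1cc(C)c(=O)[nH]c1=O` is different in that it carries a fluoro where compound 2 carries a methoxy. In this assay compound 1 gives >= 100000 nM, which is a limit of the assay rather than a number. Among the measured compounds shown here, the one measured step, an at least 2.5-fold lower number from compound 1 to compound 2 (0.41 log units; beyond the scatter), therefore shows that the methoxy-bearing ring lowers the number relative to the fluoro-bearing ring, with the size of that step only bounded from below by the limit of >= 100000 nM in this assay, at which 1 of the 2 values shown sits.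

Compound 3 `CCS[C@@H]1[C@H](SCC)[C@@H](Cn2cc(-c3ccccc3C(F)(F)F)nn2)O[C@H]1n1cc(C)c(=O)[nH]c1=O` differs from compound 2 by 2-(trifluoromethyl)phenyl in place of 4-methoxyphenyl on an aromatic carbon. This change removes the methoxy that accompanied the lower number and brings in a fluorine-bearing group, so a return toward a higher number is expected. Compound 3 is thus expected to give roughly 80000 nM in this assay, within a range from 30000 nM to 200000 nM, a step of a 2.1-fold higher number from compound 2 to compound 3 (0.31 log units; beyond the scatter), with a fair chance that only a limit is reported.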

Compound 3, half-maximal effective concentration: 7230 nM
Estimate against measurement, compound 3: 11-fold (1.04 log units) above; the measured number lies below the stated range.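

The result shows that a methoxy is not needed for a lower number at this aromatic carbon of the five-membered ring in this assay: replacing 4-methoxyphenyl with 2-(trifluoromethyl)phenyl gives a 5.4-fold lower number from compound 2 to compound 3 (0.73 log units; beyond the scatter). Fluorine on the aryl group does not in itself go with a higher number here, since 2-(trifluoromethyl)phenyl in place of 4-fluorophenyl gives an at least 13-fold lower number from compound 1 to compound 3 (1.14 log units; beyond the scatter). Compound 1 stands at a limit of the assay, so the size of that step is bounded from one side only: the limit of >= 100000 nM in this assay, at which 1 of the 3 values shown sits.

The 4-methoxyphenyl and 2-(trifluoromethyl)phenyl groups differ in both the substituent and its place on the phenyl ring, and the compounds shown do not separate these two changes. Where a phenyl group without a substituent, or one bearing an amine or a carboxylic acid, would fall remains open.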